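Methoxy at a New Place on a Weak Benzimidazole Series

The source may report more compounds than this note shows. Statements on the series, on what has been measured and on what is new or still open speak of the compounds shown alone.

Compound 1 `Cn1cc(-c2nc3ccccc3n2C(=O)c2ccccc2Br)c2ccccc21` gives 70100 nM in a functional assay on MCF7 cells (Homo sapiens) for inhibition, read by MTT assay, with a stated time of 24 h; on this read-out higher numbers stand for weaker inhibition of growth and lower numbers for stronger inhibition of growth. Compound 2 `COc1ccc2c(c1)c(-c1nc3ccccc3n1C(=O)c1ccccc1Br)cn2C` carries the change methoxy in place of hydrogen on an aromatic carbon and gives 55800 nM; the step of a 1.3-fold lower number from compound 1 to compound 2 (0.10 log units; within the scatter) is small. Compound 3 `Cn1cc(-c2nc3ccccc3n2C(=O)c2ccccc2)c2cc(Br)ccc21` has the same atoms as compound 1 joined differently, and the difference between the two cores is not broken down here; in this assay compound 3 gives 50300 nM, and all three numbers lie within the scatter of one another.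

Compound 4 `COc1ccccc1C(=O)n1c(-c2cn(C)c3ccc(Br)cc23)nc2ccccc21` is not yet measured. It differs from compound 3 by methoxy in place of hydrogen on an aromatic carbon, the same kind of change as that from compound 1 to compound 2, but at another place: there the methoxy sat on a ring that is part of a fused or bridged system of two rings, meta and para to a fused ring, whereas here it sits on a ring of carbon only, ortho to a large group. As the earlier step was within the scatter, a similarly small step a 1.1-fold lower number from compound 3 to compound 4 (0.05 log units; within the scatter) is expected in this assay, and compound 4 is estimated at 45000 nM, between 18000 nM and 110000 nM.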

Compound 4, concentration for 50% growth inhibition: 36200 nM
Beside the measured number, compound 4's estimate is 1.2-fold (0.09 log units) above it; low and high end bracket the measured number.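

Methoxy in place of hydrogen on an aromatic carbon gives a 1.4-fold lower number from compound 3 to compound 4 (0.14 log units; within the scatter) in this assay and so stays small, as it did on the core of compound 1. Set side by side, the two steps do not differ, although the methoxy sits at a different place in each: the same change on two cores in this assay, a 1.3-fold lower number (0.10 log units; within the scatter) from compound 1 to compound 2 and a 1.4-fold lower number (0.14 log units; within the scatter) from compound 3 to compound 4, 1.1-fold (0.04 log units) apart, within the scatter of two such steps. This shows that the change behaved alike on these two cores, moving the number by no more than the scatter on either, but it does not show a real gain in inhibition of growth on either core, and one pair of steps sets no rule for the wider series.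

The compounds shown leave open whether another group on the same ring of carbon only, such as an amine, a carboxylic acid or a longer chain, would give a step beyond the scatter. They also leave open whether both methoxy groups together on one compound would move the number further than either does alone.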